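Dimethylamino for Acetyl: Expected Cytotoxicity of Compound 4

The compounds below may be only part of what the source reports. "The series", "measured", "known", "first", "only" and "open" are said of these compounds alone.

Compound 1 `COc1cc(C)cc(-c2c(-c3ccnc(-c4ccc(C(C)=O)cc4)c3)cnn2CC#N)c1`: 92%
Compound 2 `COc1cc(C)cc(-c2nn(CC#N)cc2-c2ccc(-c3cccc(C(C)=O)c3)nc2)c1`: 83%
Compound 3 `COc1cc(C)cc(-c2nn(CC#N)cc2-c2ccnc(-c3ccc(N(C)C)cc3)c2)c1`: 96%

In a functional assay on MDA-MB-468 cells (Homo sapiens) for cytotoxicity, read by sulforhodamine B assay, with a stated time of 48 h, tested at 0.001 uM (on this read-out lower numbers stand for a stronger effect and higher numbers for a weaker effect at the one concentration tested), compound 1 gives 92%. Among the three numbers this is the second highest. Compound 3 gives 96%, a number within the scatter of compound 1, and compound 2 gives 83%, also within the scatter of compound 1. Going by the values given here, no two of these three compounds differ in only one place, so no measured step between them can be drawn.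

Compound 4 `COc1cc(C)cc(-c2c(-c3ccnc(-c4ccc(N(C)C)cc4)c3)cnn2CC#N)c1` has not yet been measured. It differs from compound 1 in one place: dimethylamino in place of acetyl on an aromatic carbon. Compound 3 already carries a dimethylamino group and gives 96%, which is within the scatter of compound 1. On this basis the step of a number 2 percentage points higher from compound 1 to compound 4 (within the scatter) is expected to be small and not beyond the scatter. Compound 4 is therefore expected to give 94%, with a range from 84% to 100%.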

Compound 4, a percentage reported as activity, at one concentration (the size of the read-out at that concentration, not a potency): 93%
Estimate against measurement, compound 4: 1 percentage points above, within the range that was stated.
By their numbers in this assay, from the lowest: compounds 2, 1, 4 and 3 (each within the scatter of the next, the first and the last beyond it).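

Placing dimethylamino in place of acetyl on an aromatic carbon para to a large group gives a number 1 percentage points higher from compound 1 to compound 4 (within the scatter) in this assay, and this is the only step in the set that isolates a single change. Going by these compounds alone, at the one concentration tested, the read-out therefore does not separate 4-acetylphenyl from 4-(dimethylamino)phenyl on the core of compound 1, something the earlier compounds, which differed in more than one place, could not show. No measurement presented here explains why the two groups read alike.

The compounds shown leave open whether a carboxylic acid or a morpholine on this same aromatic carbon would give a step beyond the scatter. They also leave open whether acetyl and dimethylamino would still read alike at a higher concentration.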